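The compounds below may be only part of what the source reports. "The series", "measured", "known", "first", "only" and "open" are said of these compounds alone.

Measured compounds:
- compound 1, `Nc1nc(Cl)c2ncn(Cc3ccccc3CCl)c2n1`: 21900 nM
- compound 2, `ClCc1ccc(Cn2cnc3c(Cl)nc(Cl)nc32)cc1`: 5250 nM

Of the compounds shown here, two have numbers so far in a functional assay on ACHN cells (Homo sapiens) for cytotoxicity, read by sulforhodamine B assay, with a stated time of 48 h; on this read-out higher numbers stand for weaker inhibition of growth and lower numbers for stronger inhibition of growth. Compound 1, `Nc1nc(Cl)c2ncn(Cc3ccccc3CCl)c2n1`, gives 21900 nM, the highest of the two. Going by the values given here, compound 2, `ClCc1ccc(Cn2cnc3c(Cl)nc(Cl)nc32)cc1`, gives 5250 nM, a lower number that lies beyond the scatter of the assay; compound 2 differs from compound 1 in more than one place, so no single step connects them and the gap is reported only as what the two values show.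

Compound 3, `ClCc1ccccc1Cn1cnc2c(Cl)ncnc21`, has not yet been measured. Against compound 1 its structure shows one change: hydrogen in place of amino on an aromatic carbon. Among the compounds with values here, no measured pair isolates this change, so its effect in this assay cannot be read from the data. Within the data shown here, what is known is only that the sole other compound, compound 2, with a different set of changes, stands lower than compound 1. On that thin basis the expected step of a 1.5-fold lower number from compound 1 to compound 3 (0.16 log units; within the scatter) is a small move toward a lower number, one that may well fall within the scatter. Compound 3 is therefore estimated at 15000 nM, with a range from 5000 nM to 45000 nM.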

Compound 3, concentration for total growth inhibition: 6160 nM
Beside the measured number, compound 3's estimate is 2.4-fold (0.39 log units) above it; low and high end bracket the measured number.
By their numbers in this assay, from the lowest: compounds 2 and 3 (each within the scatter of the next); then compound 1.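

In this assay, placing hydrogen instead of amino on the aromatic carbon between two ring nitrogen atoms gives a 3.6-fold lower number from compound 1 to compound 3 (0.55 log units; beyond the scatter) and provides the first single-place comparison among these compounds. This step is modest but lies beyond the scatter, so this position on the core of compound 1 can affect the read-out, and the amino group is not required there for growth inhibition, as compound 3 has the lower number. No available evidence bears on why the amino and hydrogen forms differ.

The two forms alone do not show how other groups at this position would compare, such as a methyl, a methoxy or a dimethylamino group, or whether a chloro group there would stand apart from hydrogen when all else is held equal. From the compounds shown here alone, it also remains open whether the same change would give a similar step in a compound with a different substituent in place of the chloromethyl group, such as a hydroxymethyl group.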